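Phenyl group changes on the shared core: working notes

The source may report more compounds than this note shows. Statements on the series, on what has been measured and on what is new or still open speak of the compounds shown alone.

Measured so far in a functional assay on HCT-8 cells (Homo sapiens) for cytotoxicity; on this read-out lower numbers stand for an effect already at smaller amounts and higher numbers for an effect only at larger amounts of compound:
- compound 1 `COC1=C(C)C(=O)/C(=C(O)/C=C/c2ccccc2C)C(=O)C1(C)C`: 4 ug/mL
- compound 2 `COC1=C(C)C(=O)/C(=C(O)/C=C/c2cc(C)cc(C)c2)C(=O)C1(C)C`: 2.9 ug/mL

Compound 2 cannot be separated from compound 1 on these two numbers. Among the compounds with values here, the only measured step, a 1.4-fold lower number from compound 1 to compound 2 (0.14 log units; within the scatter), exchanges 2-methylphenyl for 3,5-dimethylphenyl. Compound 3 `C=Cc1ccccc1/C=C/C(O)=C1/C(=O)C(C)=C(OC)C(C)(C)C1=O` brings the next exchange at the same place: 2-vinylphenyl in place of 3,5-dimethylphenyl on a double-bonded chain carbon bound to a double-bonded chain carbon. Within the data shown here, no compound with a 2-vinylphenyl group has been measured, so that single step is the only guide, and it bears on this exchange only indirectly. With so small a step on record for compound 2, none beyond the scatter is expected in this assay. The expected change is a 1.2-fold higher number from compound 2 to compound 3 (0.07 log units; within the scatter). Compound 3 is estimated at 3.4 ug/mL, with an expected range of 1.5 ug/mL to 7.5 ug/mL.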

Compound 3, concentration for half-maximal effect: 2.1 ug/mL
Estimate against measurement, compound 3: 1.6-fold (0.21 log units) above, and the stated range covers the measured number.
By their numbers in this assay, from the lowest: compounds 3, 2 and 1 (each within the scatter of the next).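

In this assay the place on a double-bonded chain carbon bound to a double-bonded chain carbon accepts 2-vinylphenyl as well as 3,5-dimethylphenyl, with a 1.4-fold lower number from compound 2 to compound 3 (0.14 log units; within the scatter) and no separation between the two groups. The earlier compounds shown here held no change of vinyl in place of methyl on an aromatic carbon; that exchange gives a 1.9-fold lower number from compound 1 to compound 3 (0.28 log units; within the scatter), so a double bond outside the aromatic ring also leaves the read-out unresolved from the methyl analogue. No measurement on hand bears on why these groups give such similar numbers.

Within the data shown here, all three compounds carry only carbon and hydrogen substituents on the phenyl group, so the series so far spans a narrow range of groups at this place. Open, on these data alone, is whether an amine, a carboxylic acid or a longer chain there would give a step beyond the scatter.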